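Swapping amino for nitro in a well-tolerated compound

A few compounds are considered here, and "the series" means these few. Any claim that something is new, unique, unknown or untested is made for them only; others in the source may bear on it.

In an ADME assay on HepG2 cells (Homo sapiens) for cytotoxicity, read by MTT assay, with a stated time of 72 h (a lower number here means that less compound is tolerated, a higher number that more compound is tolerated), compound 1 (`CS(=O)(=O)Cc1nc2c(Br)cc(Cl)cn2c1N`) gives > 125000 nM, which is a limit and not a number. Compound 2 (`Cc1cc(Sc2ccc(Cl)cc2)c2nc(CS(=O)(=O)c3ccccc3)c([N+](=O)[O-])n2c1`), which carries a nitro group, gives > 62500 nM, also a limit. Compound 3 (`CS(=O)(=O)Cc1nc2c(Br)cc(Cl)cn2c1[N+](=O)[O-]`) has nitro in place of amino on an aromatic carbon of the core of compound 1: nitro in place of amino on an aromatic carbon. For the measured compounds named here, no measured pair shows this change, so the expectation rests loosely on compound 2 and its > 62500 nM. The expected step is an at least 1.7-fold lower number from compound 1 to compound 3 (0.25 log units; that floor lies within the scatter), modest and towards less compound tolerated. For compound 3, the estimated value is 70000 nM, with a range of 20000 nM to 125000 nM.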

Compound 3, half-maximal cytotoxic concentration: 45000 nM
Compound 3: middle estimate off by 1.6-fold (0.19 log units), on the high side; the range from low to high includes it.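

Nitro in place of amino on this aromatic carbon gives an at least 2.7-fold lower number from compound 1 to compound 3 (0.44 log units; beyond the scatter) in this assay. For the compounds shown here, compound 3 thus gives the first actual number in this set, showing that this change on the core of compound 1 can bring a measurable cytotoxic concentration. The step is only a floor, not a full size, because compound 1 gives a limit and not a number: the limit of > 125000 nM in this assay, at which 1 of the 3 values shown sits.

From the compounds shown here alone, whether a nitrile or a carboxylic acid on the same carbon would fall nearer compound 1 or compound 3 remains open. So does how far the true step extends.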